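A Hydroxyphenyl Replacing a Trisubstituted Aryl: Expected Outcome

This account rests on a few compounds, and the source may have more. Where it says the series, first, only, none or still open, it means among the compounds named here.

The measured compounds in an ADME assay on the whole organism for cytotoxicity, with Artemia salina as the target, with a stated time of 24 h (a lower number here means that less compound is needed, a higher number that more compound is needed for the effect), are:
compound 1 `COc1ccc(/C=C/C(=O)c2ccccc2NC(=O)NS(=O)(=O)c2ccc(C)cc2)cc1`, giving 28.1 ug/mL
compound 2 `COc1ccc(/C=C/C(=O)c2ccccc2NC(=O)NS(=O)(=O)c2ccc(C)cc2)cc1OC`, giving 12.9 ug/mL
compound 3 `CCc1cc(/C=C/C(=O)c2ccccc2NC(=O)NS(=O)(=O)c2ccc(C)cc2)cc(OC)c1OC`, giving 19.2 ug/mL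

Compound 3 stands second highest of the three numbers, but both neighbours lie within the scatter: a 1.5-fold lower number from compound 1 to compound 3 (0.17 log units; within the scatter) and a 1.5-fold higher number from compound 2 to compound 3 (0.17 log units; within the scatter). Going by the values given here, the only step beyond the scatter is a 2.2-fold lower number from compound 1 to compound 2 (0.34 log units; beyond the scatter), a modest shift.

Compound 4 `Cc1ccc(S(=O)(=O)NC(=O)Nc2ccccc2C(=O)/C=C/c2ccccc2O)cc1` differs from compound 3 in one place: 2-hydroxyphenyl in place of 3-ethyl-4,5-dimethoxyphenyl on a double-bonded chain carbon bound to a double-bonded chain carbon. This change bears on the same position as the steps already seen. Two of those steps, from compound 1 and from compound 2 to compound 3, stayed within the scatter, while adding a methoxy group lowered the number modestly in the step from compound 1 to compound 2. Compound 4 carries no methoxy group on that ring, so a somewhat higher number is expected, estimated as a 1.4-fold higher number from compound 3 to compound 4 (0.13 log units; within the scatter). For compound 4, the estimate is 26 ug/mL, with a range from 12 ug/mL to 55 ug/mL.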

Compound 4, concentration for half-maximal effect: 32.3 ug/mL
The estimate for compound 4 lay 1.2-fold (0.09 log units) below the measured number, and the stated range covers the measured number.
By their numbers in this assay, from the lowest: compounds 2, 3, 1 and 4 (each within the scatter of the next, the first and the last beyond it).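

In this assay this position accepts a smaller ring group, 2-hydroxyphenyl with a hydrogen-bond donor in place of 3-ethyl-4,5-dimethoxyphenyl with none, and the outcome is a 1.7-fold higher number from compound 3 to compound 4 (0.23 log units; within the scatter) and, measured against the 4-methoxyphenyl group, a 1.1-fold higher number from compound 1 to compound 4 (0.06 log units; within the scatter) with both steps read as no real change. Set against the 3,4-dimethoxyphenyl group, the same ring gives a 2.5-fold higher number from compound 2 to compound 4 (0.40 log units; beyond the scatter) so compound 2 now lies beyond the scatter from both compound 1 and compound 4, while compound 3 lies beyond it from neither. Nothing measured here explains why these steps come out as they do.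

On these data alone, each change here swaps a whole ring group, so the share of the hydroxy group alone stays unknown. A plain phenyl, or a phenyl carrying an amine or a carboxylic acid, at this place would test how far the position's tolerance extends.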